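The source may hold more compounds than are shown below. What is called first, only, known or untested is meant among the compounds shown, and "the series" means these compounds.

In an in vivo ADME assay on the whole organism (strain BALB/c) for pharmacokinetics, with Mus musculus as the target, read by LC-MS, at a dose of 5 mg/kg by the oral route (on this read-out higher numbers stand for fast clearance and lower numbers for slow clearance), compound 1 `CCCS(=O)(=O)c1ccc(C)c(C#Cc2cc(C#N)ccc2OCC(=O)O)c1` gives 18.3 mL/min/kg and compound 3 `CC(C)S(=O)(=O)c1ccc(Cl)c(C#Cc2cc(Cl)ccc2OCC(=O)O)c1` gives 11.7 mL/min/kg. Compound 2 `CCCS(=O)(=O)c1cccc(C#Cc2cc(Cl)ccc2OCC(=O)O)c1` gives 5 mL/min/kg, the lowest of the three numbers, and both gaps lie beyond the scatter. Compound 4 `CCCS(=O)(=O)c1ccc(F)c(C#Cc2cc(Cl)ccc2OCC(=O)O)c1` carries fluoro in place of hydrogen on an aromatic carbon of compound 2, para to the propylsulfonyl group: fluoro in place of hydrogen on an aromatic carbon. Within the data shown here, no measured pair shows this change alone. Compound 3, with chloro on that carbon, gives 11.7 mL/min/kg, but it also differs elsewhere, so it supports only a cautious expectation of a small rise. The expected step of a 1.4-fold higher number from compound 2 to compound 4 (0.15 log units; within the scatter) stays within the scatter. For compound 4 the estimate is 7 mL/min/kg, with an expected range of 3.5 mL/min/kg to 14 mL/min/kg.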

Compound 4, clearance: 6.67 mL/min/kg
Beside the measured number, compound 4's estimate is 1.0-fold (0.02 log units) above it, and the stated range covers the measured number.
By their numbers in this assay, from the lowest: compounds 2, 4, 3 and 1 (each within the scatter of the next, the first and the last beyond it).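

In this assay, fluoro in place of hydrogen on this aromatic carbon, para to a propylsulfonyl group, now has a step of its own, a 1.3-fold higher number from compound 2 to compound 4 (0.13 log units; within the scatter), and that step lies within the scatter. Compound 3 could not show this, since it also differs elsewhere, whereas compound 4 differs from compound 2 in this one place and cannot be told apart from it on clearance. No measurement given here explains this result.

On these data alone, what a methoxy group or an amine on this carbon would give remains open. So does whether fluoro behaves alike alongside the nitrile of compound 1.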